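The compounds below may be only part of what the source reports. "The series", "measured", "known", "first", "only" and "open" are said of these compounds alone.

Compound 3 `ClCc1ccccc1Cn1cnc2c(Cl)nc(Cl)nc21` gives the lowest of the three numbers recorded so far in a functional assay on EKVX cells (Homo sapiens) for cytotoxicity, read by sulforhodamine B assay, with a stated time of 48 h (on this read-out lower numbers stand for higher toxicity in this test and higher numbers for lower toxicity in this test), where compound 3 gives 5880 nM. Its nearest neighbour on this read-out is compound 2 `ClCc1ccccc1Cn1cnc2ncnc(Cl)c21`, which in this assay gives 45700 nM, and the furthest is compound 1 `Nc1nc(Cl)c2ncn(Cc3ccccc3CCl)c2n1`, which in this assay gives 60300 nM.

Compound 4 `ClCc1ccccc1Cn1cnc2c(Cl)ncnc21` has not yet been measured. It differs from compound 3 in one place: hydrogen in place of chloro on an aromatic carbon.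

Among the compounds with values here, only one measured step is directly comparable, and it runs in the opposite sense, a chloro entering where an amino had been: a 10-fold lower number from compound 1 to compound 3 (1.01 log units; beyond the scatter). That step shows that the substituent pattern on the core of compound 3 carries a large weight in this assay, and that the dichloro compound 3 gives the lowest number of the set. Compound 2, which shares the benzyl group and the single chloro but sits differently on its core, gives a markedly higher number than compound 3. The change to compound 4 removes a chloro rather than adding one, so the expected step is a 3.4-fold higher number from compound 3 to compound 4 (0.53 log units; beyond the scatter), upwards. Compound 4 is therefore estimated at 20000 nM, with a range from 6000 nM to 60000 nM.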

Compound 4, concentration lethal to 50% of the cells: 37200 nM
The estimate for compound 4 lay 1.9-fold (0.27 log units) below the measured number, and the stated range covers the measured number.
By their numbers in this assay, from the lowest: compound 3; then compounds 4, 2 and 1 (each within the scatter of the next).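

Taking away the chloro that sits between two ring nitrogen atoms gives a 6.3-fold higher number from compound 3 to compound 4 (0.80 log units; beyond the scatter) in this assay, so this single chloro accounts for a clear part of the low number of compound 3, and the other chloro on the core does not produce that number alone. Hydrogen and amino at this same carbon can now also be compared directly, and a 1.6-fold lower number from compound 1 to compound 4 (0.21 log units; within the scatter) shows that this assay does not separate the two groups, which leaves chloro as the only one of the three whose step is beyond the scatter. The data offer no explanation for why chloro stands apart at this position.

On these data alone, whether the low number depends on chloro in particular remains open, since a fluoro, a bromo, a methyl or a methoxy group at this carbon could fall on either side. As far as these compounds go, all four compounds also share the chloromethyl group on the benzyl ring, so what a hydroxymethyl or a plain methyl group in its place would do to the effect of this chloro also remains unknown.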